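From a Phenylethynyl Limit to a Methoxyphenyl Ethenyl Chain

The source may hold more compounds than are shown below. What is called first, only, known or untested is meant among the compounds shown, and "the series" means these compounds.

In a functional assay on cells (T-cell line, Homo sapiens) for inhibition (on this read-out higher numbers stand for weaker inhibition and lower numbers for stronger inhibition), compound 1 `CCCCCCN1CCC(COC(c2ccccc2)c2ccccc2)CC1` gives 5500 nM, and compound 2 `CCCCCCCCCCN1CCC(COC(c2ccccc2)c2ccccc2)CC1` gives 2600 nM. These two differ by a 2.1-fold lower number from compound 1 to compound 2 (0.33 log units; beyond the scatter).

Compound 3 `C(#Cc1ccccc1)CN1CCC(COC(c2ccccc2)c2ccccc2)CC1` carries 2-phenylethynyl on the same carbon. Compound 3 reads > 20000 nM, which is a limit of the assay and not a number. Within the data shown here, it therefore has no exact place on the scale, and the limit of > 20000 nM in this assay, at which 1 of the 3 values shown sits, is the only such reading so far.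

Compound 4 `COc1ccc(/C=C/CN2CCC(COC(c3ccccc3)c3ccccc3)CC2)cc1` replaces that group with 2-(4-methoxyphenyl)ethenyl, on a saturated chain carbon bound to an amine nitrogen in a ring: 2-(4-methoxyphenyl)ethenyl in place of 2-phenylethynyl on a saturated chain carbon bound to an amine nitrogen in a ring.

Among the measured compounds shown here, two measured steps bear most directly on this change, since both introduce the group that now leaves. They are an at least 3.6-fold higher number from compound 1 to compound 3 (0.56 log units; beyond the scatter) and an at least 7.6-fold higher number from compound 2 to compound 3 (0.88 log units; beyond the scatter). Neither step tests the entering group, so they give only a rough guide. Removing 2-phenylethynyl may reverse part of that rise, so a modest move to a lower number is expected in this assay, though another reading at the limit remains possible.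

The expected change is an at least 2.0-fold lower number from compound 3 to compound 4 (0.30 log units; that floor lies within the scatter).

For compound 4, the estimated value is 10000 nM, with an expected range from 3000 nM to 20000 nM.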

Compound 4, half-maximal inhibitory concentration: 4300 nM
Compound 4: middle estimate off by 2.3-fold (0.37 log units), on the high side; measured number inside the range.
By their numbers in this assay, from the lowest: compounds 2, 4 and 1 (each within the scatter of the next, the first and the last beyond it). At a limit, above all of these: compound 3.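

The step away from 2-phenylethynyl shows that this place, a saturated chain carbon bound to an amine nitrogen in a ring, can carry an unsaturated group ending in an aromatic ring without the reading going to a limit: 2-(4-methoxyphenyl)ethenyl gives (an at least 4.6-fold lower number from compound 3 to compound 4 (0.66 log units; beyond the scatter)) in this assay. Set against the plain chains, the same group gives (a 1.7-fold higher number from compound 2 to compound 4 (0.22 log units; within the scatter)) and (a 1.3-fold lower number from compound 1 to compound 4 (0.11 log units; within the scatter)), both within the scatter, so compound 4 cannot be told apart from compound 1 or compound 2 on this read-out. Compound 3 remains a limit and not a number, the only such reading in this assay: the limit of > 20000 nM in this assay, at which 1 of the 4 values shown sits.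

The compounds shown leave open whether the double bond in place of the triple bond or the entering oxygen accounts for the step, for the two arrive together in compound 4. Whether an amine or a carboxylic acid in place of the methoxy of 2-(4-methoxyphenyl)ethenyl would hold the reading at this level also stays unanswered.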